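The source may hold more compounds than are shown below. What is called first, only, known or untested is meant among the compounds shown, and "the series" means these compounds.

Working notes on the series. The shared core is that of compound 1 `O=CCc1c(-c2ccccc2Cl)c2cc(Cl)ccc2[nH]c1=O`, which in an ADME assay on HepG2 2.2.15 cells (Homo sapiens) for cytotoxicity (on this read-out higher numbers stand for lower toxicity in this test and lower numbers for higher toxicity in this test), gives 120000 nM. Compound 2 `CC(C)C(=O)OCCc1c(-c2ccccc2Cl)c2cc(Cl)ccc2[nH]c1=O` gives 62000 nM in this assay, and compound 3 `CCCCC(=O)OCCc1c(-c2ccccc2Cl)c2cc(Cl)ccc2[nH]c1=O` gives 200000 nM. Compound 1 thus stands second highest of the three numbers; its nearest neighbour is compound 3 and its furthest compound 2, and both of those gaps lie within the scatter.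

Compound 4 `CCOCC(=O)OCCc1c(-c2ccccc2Cl)c2cc(Cl)ccc2[nH]c1=O` is the next member. Its difference from compound 1: (((ethoxymethyl)carbonyl)oxy)methyl in place of formyl on a saturated chain carbon bound to an aromatic carbon. Among the compounds with values here, two measured steps bear on this change, since each also replaces formyl at the same place: a 1.9-fold lower number from compound 1 to compound 2 (0.29 log units; within the scatter) and a 1.7-fold higher number from compound 1 to compound 3 (0.22 log units; within the scatter). Neither left the scatter, and they point opposite ways. Within the data shown here, the one step beyond the scatter, a 3.2-fold higher number from compound 2 to compound 3 (0.51 log units; beyond the scatter), lies between the two entering groups themselves, so the identity of the entering group can matter modestly. For compound 4 no step beyond the scatter is expected in either direction; the expected step is a 1.1-fold higher number from compound 1 to compound 4 (0.03 log units; within the scatter). Compound 4 is therefore estimated at 130000 nM, with a range from 50000 nM to 320000 nM.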

Compound 4, half-maximal cytotoxic concentration: 130000 nM
Compound 4: the middle estimate sits on the measured number at the digits printed; the range from low to high includes it.
By their numbers in this assay, from the lowest: compounds 2, 1, 4 and 3 (each within the scatter of the next, the first and the last beyond it).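

The third replacement of formyl on a saturated chain carbon bound to an aromatic carbon again stays within the scatter, as a 1.1-fold higher number from compound 1 to compound 4 (0.03 log units; within the scatter) shows, now with an entering group of 8 heavy atoms and 3 hydrogen-bond acceptors. On the carbonyl carbon, the ethoxy-for-propyl change also stays within the scatter in this assay, as a 1.5-fold lower number from compound 3 to compound 4 (0.19 log units; within the scatter) shows, while a 2.1-fold higher number from compound 2 to compound 4 (0.32 log units; beyond the scatter) is modest. Both steps beyond the scatter now start from compound 2, with isopropyl on the carbonyl carbon, although a 1.9-fold lower number from compound 1 to compound 2 (0.29 log units; within the scatter) goes against any separation of compound 2 from compound 1.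

On these data alone, whether an amine or a carboxylic acid at the end of the chain, or a chain longer than butyl on the carbonyl carbon, would move the number beyond the scatter remains open. The data shown give no explanation for these steps.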